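Working notes: chain extension from compound 3 to compound 4

The source may report more compounds than this note shows. Statements on the series, on what has been measured and on what is new or still open speak of the compounds shown alone.

compound 1 `CC(=O)Nc1ccc2[nH]c(C)nc2c1`: 1260000 nM
compound 2 `Clc1cccc(Cc2nc3ccccc3[nH]2)c1`: 22900 nM
compound 3 `CCCc1nc2cc(C)c(C)cc2[nH]1`: 110000 nM

In an ADME assay on microsomes from liver for inhibition of cytochrome P450 2B1 (Rattus norvegicus) (on this read-out higher numbers stand for weaker inhibition and lower numbers for stronger inhibition), compound 1 gives 1260000 nM, compound 2 gives 22900 nM and compound 3 gives 110000 nM. Compound 3 thus stands second highest of the three numbers, beyond the scatter from both others: compound 2 sits lower, compound 1 higher. Compound 4 `CCCCc1nc2cc(C)c(C)cc2[nH]1` differs from compound 3 only by methyl in place of hydrogen on a saturated chain carbon, three bonds along the chain from an aromatic carbon. Among the compounds with values here, no measured pair shows this change, so nothing in the data fixes its size. A modest step toward a lower number is expected, of a size that may not clear the scatter; the expected step is a 1.8-fold lower number from compound 3 to compound 4 (0.26 log units; within the scatter). For compound 4 the estimate is 60000 nM, with a range from 20000 nM to 200000 nM.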

Compound 4, half-maximal inhibitory concentration in the cytochrome P450 2B1 assay: 55000 nM
Estimate against measurement, compound 4: 1.1-fold (0.04 log units) above; the measured number falls inside the stated range.
By their numbers in the cytochrome P450 2B1 assay, from the lowest: compound 2; then compounds 4 and 3 (each within the scatter of the next); then compound 1.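

Within the data shown here, this is the first pair that differs in one place, and it gives the first direct read on the chain end: in the cytochrome P450 2B1 assay, the propyl to butyl change gives a 2.0-fold lower number from compound 3 to compound 4 (0.30 log units; within the scatter). In a physicochemical assay for lipophilicity (on this read-out higher numbers stand for higher lipophilicity and lower numbers for lower lipophilicity), compound 3 gives 3.4 and compound 4 gives 3.9. In the physicochemical assay, the same change clears the scatter, so a shift in this read-out need not come with a step beyond the scatter in inhibition: the measured partition coefficient of compound 3, 3.4, and of compound 4, 3.9, a number 0.50 log units higher (beyond the scatter)

A single pair sets no trend along the chain. On these data alone, whether a longer chain, or a chain ending in an amine or a carboxylic acid, would move the inhibition number beyond the scatter remains open.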